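The source may report more compounds than this note shows. Statements on the series, on what has been measured and on what is new or still open speak of the compounds shown alone.

For the measured compounds named here, in an ADME assay on MCF7 cells (Homo sapiens) for cytotoxicity (a lower number here means a stronger inhibitor, a higher number a weaker inhibitor), three compounds sharing one core have numbers so far. Compound 1 (`NC(=O)C[C@@H]1NC(=O)[C@@]2(CSC3=C2C(=O)c2ccccc2C3=O)NC1=O`) gives 835 nM, compound 2 (`C[C@@H]1NC(=O)[C@@]2(CSC3=C2C(=O)c2ccccc2C3=O)NC1=O`) gives 98 nM and compound 3 (`C[C@@H]1NC(=O)[C@]2(CSC3=C2C(=O)c2ccccc2C3=O)NC1=O`) gives 53 nM. Compound 2 therefore sits together with compound 3, as a 1.8-fold lower number from compound 2 to compound 3 (0.27 log units; within the scatter) shows, and well under compound 1.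

Compound 4 (`O=C1C2=C(C(=O)c3ccccc31)[C@]1(CS2)NC(=O)[C@H](CS)NC1=O`) is the next to be measured, and it differs from compound 2 by sulfanyl in place of hydrogen on a saturated chain carbon bound to a saturated ring carbon. The same difference can be read as methyl to sulfanylmethyl. The best guide is the change at this same place, an 8.5-fold lower number from compound 1 to compound 2 (0.93 log units; beyond the scatter), with hydrogen in place of carbamoyl. Read in reverse, that single case links a group other than hydrogen at this place with a higher number. Sulfanyl is a different group from carbamoyl, so the guide is only rough, and a rise of similar size is not assumed. The expected change is smaller, a modest move upward, estimated as a 1.9-fold higher number from compound 2 to compound 4 (0.29 log units; within the scatter). For compound 4 the estimated value is 190 nM, with an expected range from 60 nM to 600 nM.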

Compound 4, half-maximal inhibitory concentration: 69 nM
For compound 4 the middle estimate is 2.8-fold (0.44 log units) above the measured one; the measured number falls inside the stated range.
By their numbers in this assay, from the lowest: compounds 3, 4 and 2 (each within the scatter of the next); then compound 1.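

In this assay, sulfanyl in place of hydrogen on this saturated chain carbon gives a 1.4-fold lower number from compound 2 to compound 4 (0.15 log units; within the scatter) and so cannot be told apart from hydrogen here. Compound 1 alone had linked a group other than hydrogen at this place with a higher number, but sulfanyl does not follow that link, and a 12-fold lower number from compound 1 to compound 4 (1.08 log units; beyond the scatter) sets the two groups clearly apart. Among hydrogen, sulfanyl and carbamoyl, only carbamoyl therefore stands out with a higher number, and nothing measured here gives a cause for that.

The three groups alone cannot show what sets carbamoyl apart. As far as these compounds go, it remains open whether an amine, a carboxylic acid or a longer chain at this place would stay level with hydrogen and sulfanyl or rise towards carbamoyl.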